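Compound 4: pyrrolidinylcarbonyl in place of ethylamino on the pyridyl ether

The source may hold more compounds than are shown below. What is called first, only, known or untested is meant among the compounds shown, and "the series" means these compounds.

Measured so far:
Compound 1 `CC(C)Cc1cncc(OC[C@@H]2CCCN2C)c1`, 0.21 nM
Compound 2 `CN1CCC[C@H]1COc1cncc(N)c1`, 0.63 nM
Compound 3 `CCNc1cncc(OC[C@@H]2CCCN2C)c1`, 3.7 nM

All values come from an assay on membranes from brain for displacement of a labelled ligand from Neuronal acetylcholine receptor; alpha4/beta2 (Rattus norvegicus); on this read-out higher numbers stand for weaker inhibition and lower numbers for stronger inhibition. Compound 3 gives the highest number of the three, with compound 2 nearest and compound 1 furthest away. The steps into compound 3 are both losses: an 18-fold higher number from compound 1 to compound 3 (1.25 log units; beyond the scatter) and a 5.9-fold higher number from compound 2 to compound 3 (0.77 log units; beyond the scatter); also a 3.0-fold higher number from compound 1 to compound 2 (0.48 log units; beyond the scatter).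

Compound 4 `CN1CCC[C@H]1COc1cncc(C(=O)N2CCCC2)c1` carries the change ((pyrrolidin-1-yl)carbonyl in place of ethylamino on an aromatic carbon). Going by the values given here, no measured pair covers a carbonyl-linked group on this carbon, so the relevant steps are only indirect: replacing isobutyl on this carbon cost potency twice, and the group entering is neither of those. The large loss from compound 1 to compound 3 sets the scale against which this is judged. Relative to that large loss, the expected step for compound 4 is one of uncertain direction and probably small, namely a 1.6-fold higher number from compound 3 to compound 4 (0.21 log units; within the scatter). Compound 4 is therefore estimated at 6 nM, within 1.5 nM to 30 nM.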

Compound 4, inhibition constant: 19.9 nM
For compound 4 the middle estimate is 3.3-fold (0.52 log units) below the measured one; measured number inside the range.
By their numbers in this assay, from the lowest: compound 1; then compound 2; then compound 3; then compound 4.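

In this assay the (pyrrolidin-1-yl)carbonyl group gives the weakest inhibition yet seen on this aromatic carbon, against ethylamino (a 5.4-fold higher number from compound 3 to compound 4 (0.73 log units; beyond the scatter)), amino (a 32-fold higher number from compound 2 to compound 4 (1.50 log units; beyond the scatter)) and isobutyl (a 95-fold higher number from compound 1 to compound 4 (1.98 log units; beyond the scatter)). Going by these compounds alone, this position therefore spans a wider range than the earlier compounds showed, and a carbonyl-linked ring lies at its weak end. Nothing available accounts for this order.

The compounds shown do not separate the carbonyl from the pyrrolidine ring. A primary carboxamide, or a pyrrolidine bonded directly to this carbon, would make that separation.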